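The source may hold more compounds than are shown below. What is called first, only, known or untested is meant among the compounds shown, and "the series" means these compounds.

In a functional assay on HepG2 cells (Homo sapiens) for antiproliferative activity, read by MTT assay, with a stated time of 72 h (on this read-out higher numbers stand for weaker inhibition and lower numbers for stronger inhibition), compound 1 `O=c1nc2oc(C3CC3)c(C#CC3CC3)c2cn1Cc1cn(Cc2ccccc2)nn1` gives 2670 nM. Compound 2 `CCCCCCC#Cc1c(CCCCCC)oc2nc(=O)n(Cc3cn(Cc4ccccc4)nn3)cc12`, measured in this assay, gives 25800 nM. Compound 3 `O=c1nc2oc(C3CC3)cc2cn1Cc1cn(-c2ccc(Cl)cc2)nn1` is different in kind: in this assay compound 3 yields only a limit, > 100000 nM, and not a number. Compound 3 thus sits at the limit of > 100000 nM in this assay, at which 1 of the 3 values shown sits, and where it truly stands among the three cannot be read from the numbers shown.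

Compound 4 `O=c1nc2oc(CCCCl)cc2cn1Cc1cn(-c2ccc(Cl)cc2)nn1` differs from compound 3 in a single place: 3-chloropropyl in place of cyclopropyl on an aromatic carbon. No measured pair among these compounds carries that same change, so the data give no step to lean on. The starting point for compound 3 being a limit, the expectation for compound 4 in this assay is no movement beyond the usual scatter, with a second limit the most likely outcome. Compound 4 is therefore expected near 100000 nM, with a range from 30000 nM to 300000 nM. The expected step is accordingly a number no higher from compound 3 to compound 4 (the limit leaves the size open).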

Compound 4, half-maximal inhibitory concentration: 89800 nM
Beside the measured number, compound 4's estimate is 1.1-fold (0.05 log units) above it; measured number inside the range.
By their numbers in this assay, from the lowest: compound 1; then compound 2; then compound 4. At a limit, above all of these: compound 3.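

In this assay, 3-chloropropyl in place of cyclopropyl on an aromatic carbon, next to the ring oxygen, gives an at least 1.1-fold lower number from compound 3 to compound 4 (0.04 log units; that floor lies within the scatter). This is the first change at this position among the compounds shown, and with it compound 4 gives a number, 89800 nM, on a core with no other difference. Compound 3 stands at a limit, so the true size of the step cannot be read, and only its floor, which lies within the scatter, is known: the limit of > 100000 nM in this assay, at which 1 of the 4 values shown sits.

The compounds shown leave open whether an amine or a hydroxyl in place of the chlorine, or a longer chain, would shift the number at this position. They also leave open how 3-chloropropyl would read on the core of compound 1, which gives 2670 nM.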